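Replacing azepan-1-yl with pyrrolidin-1-yl: an expected step

This account rests on a few compounds, and the source may have more. Where it says the series, first, only, none or still open, it means among the compounds named here.

Of the compounds shown here, three have been measured in a functional assay on MDA-MB-231 cells (Homo sapiens) for inhibition, read by MTT assay, with stated times of 18 h and 4 h; on this read-out higher numbers stand for weaker inhibition and lower numbers for stronger inhibition. Compound 1 `CCCCCCCCOP(=O)(O)OCCSC(=S)N1CCCC1` gives 69000 nM, and compound 2 `CCCCCCCCCCOP(=O)(O)OCCSC(=S)N1CCCC1` gives 67000 nM. Compound 3 `CCCCCCOP(=O)(O)OCCSC(=S)N1CCCCCC1` gives 17200 nM, the lowest of the three numbers and lower than the other two by more than the usual scatter.

Compound 4 `CCCCCCOP(=O)(O)OCCSC(=S)N1CCCC1` differs from compound 3 in one place, with pyrrolidin-1-yl in place of azepan-1-yl on a thiocarbonyl carbon. Among the compounds with values here, no measured pair isolates this ring change. Within the data shown here, the only measured single-place step is a chain extension, a 1.0-fold lower number from compound 1 to compound 2 (0.01 log units; within the scatter), which lies within the scatter. This step offers indirect guidance, and it rests on just two compounds, both carrying pyrrolidin-1-yl. Compound 4 shares that group with compound 1 at 69000 nM and compound 2 at 67000 nM, while keeping the chain of compound 3. Its number is therefore expected to lie near theirs, though with wide uncertainty. The expected change is a 3.2-fold higher number from compound 3 to compound 4 (0.50 log units; beyond the scatter), a move towards weaker inhibition beyond the scatter. For compound 4 the estimated value is 55000 nM, with an expected range of 25000 nM to 110000 nM.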

Compound 4, half-maximal inhibitory concentration: 54000 nM
Compound 4: the middle estimate sits 1.0-fold (0.01 log units) above what was measured, and the stated range covers the measured number.
By their numbers in this assay, from the lowest: compound 3; then compounds 4, 2 and 1 (each within the scatter of the next).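

Within the data shown here, with the chain of compound 3 held constant, the change of azepan-1-yl to pyrrolidin-1-yl on a thiocarbonyl carbon can now be read directly in this assay: the result is a 3.1-fold higher number from compound 3 to compound 4 (0.50 log units; beyond the scatter), so in this single pair azepan-1-yl goes with the stronger inhibition, a difference that no earlier pair could isolate. The chain shows no such difference among the compounds carrying pyrrolidin-1-yl, with a 1.2-fold lower number from compound 2 to compound 4 (0.09 log units; within the scatter) and a 1.3-fold lower number from compound 1 to compound 4 (0.11 log units; within the scatter), which places all three of them within the scatter of one another and extends the earlier finding to a third chain length. Nothing available bears on why the ring change alters the number.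

The compounds shown leave open whether azepan-1-yl would keep its advantage on the longer chains of compound 1 and compound 2, as it appears here with only one chain. They also leave open how ring size relates to inhibition beyond these two rings, for instance whether piperidin-1-yl would track azepan-1-yl or pyrrolidin-1-yl, and what a ring with a second hetero atom, such as morpholin-4-yl, would give.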